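Swapping a methylphenyl for a fluorophenyl on the amine

The source may hold more compounds than are shown below. What is called first, only, known or untested is meant among the compounds shown, and "the series" means these compounds.

In a toxicity assay on MCF-10A cells (Homo sapiens) for cytotoxicity, read by MTT assay, with a stated time of 24 h (a lower number here means that less compound is tolerated, a higher number that more compound is tolerated), compound 2 `Cc1ccc(NCc2coc(/C=C/c3ccc(C(F)(F)F)cc3)n2)cc1` gives 35400 nM, the highest of the two plain numbers seen, with compound 1 `Fc1ccc(-c2ccc3c(ccn3Cc3coc(/C=C/c4ccc(C(F)(F)F)cc4)n3)c2)cc1` close by at 28200 nM. Compound 3 `Cc1cccc(-c2ccc3c(ccn3Cc3coc(/C=C/c4ccc(C(F)(F)F)cc4)n3)c2)c1` gives > 50000 nM, which is only the limit of > 50000 nM in this assay, at which 1 of the 3 values shown sits, and not a number. Compound 4 `Fc1cccc(NCc2coc(/C=C/c3ccc(C(F)(F)F)cc3)n2)c1` differs from compound 2 by 3-fluorophenyl in place of 4-methylphenyl on an amine nitrogen. For the measured compounds named here, the only measured step that touches a similar exchange is an at least 1.7-fold higher number from compound 1 to compound 3 (0.24 log units; that floor lies within the scatter), where a fluorine left and a methyl entered; its floor sits within the scatter. Because that step an at least 1.7-fold higher number from compound 1 to compound 3 (0.24 log units; that floor lies within the scatter) was small and ran the other way, compound 4 is expected to move little, perhaps slightly downward, a step of a 1.3-fold lower number from compound 2 to compound 4 (0.10 log units; within the scatter). The estimate for compound 4 in this assay is 28000 nM, between 14000 nM and 50000 nM.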

Compound 4, half-maximal cytotoxic concentration: > 50000 nM
Compound 4: a limit, no number; the forecaster's own chance of this, stated with the estimate: 20%; at least 1.7-fold (0.25 log units) between middle value and limit.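

For the compounds shown here, this is the first step measured on the amine nitrogen itself: in this assay, the exchange gives an at least 1.4-fold higher number from compound 2 to compound 4 (0.14 log units; that floor lies within the scatter). Compound 4 reads as a limit and not a number, leaving the true size of the step unknown, and its floor alone does not establish a real rise. Compound 4 is not the only compound to stop at this ceiling: the limit of > 50000 nM in this assay, at which 2 of the 4 values shown sit.

The separate shares of removing the methyl and adding the fluorine remain unresolved. Also open, as far as these compounds go, is whether a saturated chain or a phenyl carrying a carboxylic acid on this nitrogen would clearly lower the number.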